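The source may hold more compounds than are shown below. What is called first, only, known or untested is meant among the compounds shown, and "the series" means these compounds.

In an ADME assay on SH-SY5Y cells (Homo sapiens) for cytotoxicity, read by MTT assay, with a stated time of 72 h (a higher number here means a weaker inhibitor, a lower number a stronger inhibitor), three compounds sharing a core have been measured. Compound 1 `O=C(CN1CCN(C(=O)c2ccccc2)CC1)N1CCN(CCCc2c[nH]c3ccccc23)CC1` reads > 200000 nM, which is a limit of the assay and not a number. Compound 2 `COc1cccc(C(=O)N2CCN(CC(=O)N3CCN(CCCc4c[nH]c5ccccc45)CC3)CC2)c1` reads > 200000 nM, again a limit. Going by the values given here, compound 3 `O=C(CN1CCN(C(=O)c2ccccc2)CC1)N1CCN(CCCc2c[nH]c3ccc(F)cc23)CC1` gives 146000 nM, the only actual number among the three. The remaining evidence is the limit of > 200000 nM in this assay, at which 2 of the 3 values shown sit.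

Compound 4 `COc1ccc(C(=O)N2CCN(CC(=O)N3CCN(CCCc4c[nH]c5ccc(F)cc45)CC3)CC2)cc1` departs from compound 3 by a single change, (methoxy in place of hydrogen on an aromatic carbon), which is methoxy in place of hydrogen on an aromatic carbon, turning phenyl to 4-methoxyphenyl. Among the compounds with values here, two measured steps bear on this. The nearer in kind is a step that the two limits leave unreadable from compound 1 to compound 2, which also brings in a methoxy but gives no size to carry over. The other is an at least 1.3-fold lower number from compound 1 to compound 3 (0.13 log units; that floor lies within the scatter), and it concerns the fluoro that compound 4 keeps, not the methoxy. Neither step supports a move beyond the scatter in this assay, so no shift of that kind is expected in either direction, and a report of only a limit remains possible. The expected change is a 1.0-fold higher number from compound 3 to compound 4 (0.01 log units; within the scatter). Compound 4 is estimated at 150000 nM, with an expected range of 80000 nM to 280000 nM.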

Compound 4, half-maximal inhibitory concentration: 161000 nM
Estimate against measurement, compound 4: 1.1-fold (0.03 log units) below; the range from low to high includes it.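

In this assay, methoxy in place of hydrogen on an aromatic carbon now has a size that can be read, with a 1.1-fold higher number from compound 3 to compound 4 (0.04 log units; within the scatter). The earlier step that brought in a methoxy cannot be read, as it ran between two limits; here the same kind of change, para to a large group and with the fluoro kept, stays within the scatter, so this pair gives no sign that the phenyl to 4-methoxyphenyl change matters in this assay. The pair also adds a second actual number to a set in which limits remain as common as numbers: the limit of > 200000 nM in this assay, at which 2 of the 4 values shown sit.

The compounds shown leave open whether the methoxy would stay as silent without the fluoro, since the only compounds lacking it report limits and give no size to compare. They also leave open what a different group on the same aromatic carbon would do, such as an amine, a carboxylic acid or a longer chain, as a single methoxy step says nothing about groups of another kind at this place.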